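This account rests on a few compounds, and the source may have more. Where it says the series, first, only, none or still open, it means among the compounds named here.

Of the compounds shown here, two have been measured in a functional assay on HEK293 cells for agonist activity at probable G-protein coupled receptor 27 (Homo sapiens), read by a luciferase reporter and beta-arrestin recruitment, with a stated time of 10 min; a higher number here means that more compound is needed for the effect, a lower number that less compound is needed. Compound 1 `O=C(Nc1cccc(S(=O)(=O)Nc2ccccc2)c1)c1ccc(Cl)cc1Cl` gives only a limit in this assay, > 100000 nM. For the measured compounds named here, compound 2 `O=C(Nc1ccc(S(=O)(=O)Nc2ccccc2)cc1)c1ccc(Br)cc1F` gives 479 nM in this assay, which is the only number in the set, so compound 2 stands alone as the point of reference, and no step between measured compounds can be read off. Compound 3 `O=C(Nc1ccc(S(=O)(=O)Nc2ccccc2)cc1)c1ccc(Cl)nc1F` is not yet measured. It differs from compound 2 by 6-chloro-2-fluoropyridin-3-yl in place of 4-bromo-2-fluorophenyl on a carbonyl carbon. Going by the values given here, with no measured step to lean on, the expectation for this change in this assay is a modest shift toward a higher value, close to the edge of the usual scatter. Compound 3 is therefore estimated at 1000 nM, with a range from 300 nM to 4000 nM. The step from compound 2 to compound 3 that this estimate means is a 2.1-fold higher number from compound 2 to compound 3 (0.32 log units; beyond the scatter), expected rather than measured.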

Compound 3, half-maximal effective concentration: 2290 nM
Compound 3: middle estimate off by 2.3-fold (0.36 log units), on the low side, within the range that was stated.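

In this assay, 6-chloro-2-fluoropyridin-3-yl in place of 4-bromo-2-fluorophenyl on a carbonyl carbon gives a 4.8-fold higher number from compound 2 to compound 3 (0.68 log units; beyond the scatter). For the compounds shown here, this is the first step that can be read, and it shows that this place accepts a ring with a hetero atom while compound 3 still returns a number rather than a limit. The change is a double one, with a ring nitrogen entering and chlorine replacing bromine, and no measurement shown bears on the cause of the step.

Which of the two exchanges carries the step stays open, and a 4-chloro-2-fluorophenyl group or a 6-bromo-2-fluoropyridin-3-yl group on the same carbonyl carbon would separate them. Steps involving compound 1 cannot be read, and how an amine on that ring would fare is also unknown.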